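This account rests on a few compounds, and the source may have more. Where it says the series, first, only, none or still open, it means among the compounds named here.

Measured compounds in a functional assay on MDA-MB-231 cells (Homo sapiens) for antiproliferative activity, read by sulforhodamine B assay, with a stated time of 48 h; on this read-out lower numbers stand for stronger inhibition and higher numbers for weaker inhibition:
- compound 1 `COc1cc(OC)c2sc(-c3ccc(N/C=C\C(=O)c4ccc(OC)c([N+](=O)[O-])c4)c(C)c3)nc2c1` gives 10800 nM
- compound 2 `COc1cc(OC)c2sc(-c3ccc(N/C=C\C(=O)c4ccc(OC)c(O)c4)cc3)nc2c1` gives 7610 nM
- compound 3 `COc1ccc(C(=O)/C=C\Nc2ccc(-c3nc4cc(OC)c(OC)c(OC)c4s3)cc2)cc1O` gives 18100 nM

All three share an arrangement in which an aromatic amine is linked through a short unsaturated chain to a ketone, and all three give numbers in the same broad range in this assay. Compound 1 and compound 2 differ in more than one place, and the difference between their two cores is not broken down here. Compound 2 and compound 3, however, differ in just one place: methoxy in place of hydrogen on an aromatic carbon In this assay that single change made a step of a 2.4-fold higher number from compound 2 to compound 3 (0.38 log units; beyond the scatter).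

Compound 4 `COc1cc(OC)c2sc(-c3ccc(N/C=C\C(=O)c4cc(OC)c(OC)c([N+](=O)[O-])c4)c(C)c3)nc2c1` is not yet measured. It is built from compound 1 by the same kind of change: methoxy in place of hydrogen on an aromatic carbon The surroundings differ, though. In compound 3 the entering methoxy sits on a ring that is part of a fused system of two rings, ortho to two methoxy groups, meta to a fused ring and para to a fused ring; in compound 4 it sits on a six-membered aromatic ring of carbon only, ortho to one methoxy group, meta to a large group and meta to a nitro group. Within the data shown here, because the only measured example of this kind of change, a 2.4-fold higher number from compound 2 to compound 3 (0.38 log units; beyond the scatter), gave a modestly higher number, a similar direction is expected here, with less certainty since the place is not the same. The step from compound 1 to compound 4 is therefore estimated at a 1.7-fold higher number from compound 1 to compound 4 (0.22 log units; within the scatter). Compound 4 is expected to give about 18000 nM in this assay, plausibly between 8000 nM and 40000 nM.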

Compound 4, half-maximal inhibitory concentration: 7400 nM
Estimate against measurement, compound 4: 2.4-fold (0.39 log units) above; measured number below the stated range.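

In this assay, methoxy in place of hydrogen on the six-membered aromatic ring of carbon only gave a 1.5-fold lower number from compound 1 to compound 4 (0.16 log units; within the scatter), so on this core the change cannot be told apart from the ordinary variation between repeat measurements. Set beside the earlier step, the same swap of hydrogen for methoxy did not carry over with the same size from one core to the other: the same change on two cores in this assay, a 2.4-fold higher number (0.38 log units; beyond the scatter) from compound 2 to compound 3 and a 1.5-fold lower number (0.16 log units; within the scatter) from compound 1 to compound 4, 3.5-fold (0.54 log units) apart, beyond the scatter of two such steps. This does not show which difference between the two pairs matters, since both the core and the surroundings of the entering methoxy differ, and two pairs give no rule for any further core in this series.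

The compounds shown leave open how an amine or a carboxylic acid would read in this assay in the place the methoxy takes in compound 4, and whether a longer chain ending in an oxygen link to the ring would follow the step seen on compound 1 or the one seen on compound 2. They also leave open what methoxy would do if it entered the same place on both cores, which would separate the effect of the place from that of the core.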